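A few compounds are considered here, and "the series" means these few. Any claim that something is new, unique, unknown or untested is made for them only; others in the source may bear on it.

Compound 2 `CNCc1ccc(Cl)c(-c2ccccc2OC)c1` gives 1300 nM in an assay on isolated protein for binding affinity to 5-hydroxytryptamine receptor 6 (Homo sapiens) (a lower number here means a stronger inhibitor, a higher number a weaker inhibitor), the only plain number shown among the two compounds measured. Compound 1 `COc1ccccc1-c1cc(C2CCN(C)C2)ccc1Cl` sits at a limit of this assay, > 10000 nM, not at a measured number (the limit of > 10000 nM in this assay, at which 1 of the 2 values shown sits). For the measured compounds named here, the one measured step, an at least 7.6-fold lower number from compound 1 to compound 2 (0.88 log units; beyond the scatter), changed the amine itself. Compound 3 `CCNCc1ccc(Cl)c(-c2ccccc2OC)c1` differs from compound 2 by methyl in place of hydrogen on a saturated chain carbon bound to an amine nitrogen, a smaller change at the same amine, on which that step bears only indirectly. A step within the scatter is therefore expected, a 1.3-fold lower number from compound 2 to compound 3 (0.11 log units; within the scatter), and compound 3 is estimated at 1000 nM, between 350 nM and 3000 nM.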

Compound 3, inhibition constant: 1400 nM
Compound 3: middle estimate off by 1.4-fold (0.15 log units), on the low side, and the stated range covers the measured number.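

In this assay, going from methylamino to ethylamino leaves the number within the scatter, a 1.1-fold higher number from compound 2 to compound 3 (0.03 log units; within the scatter), so at this amine an added methyl brings no readable change. The advantage over 1-methylpyrrolidin-3-yl also holds for (ethylamino)methyl, an at least 7.1-fold lower number from compound 1 to compound 3 (0.85 log units; beyond the scatter). That step gives only a minimum size, since compound 1 stands at a limit of the assay: the limit of > 10000 nM in this assay, at which 1 of the 3 values shown sits. Going by these compounds, whether a longer chain such as propylamino keeps this level remains open. So does the effect of an unsubstituted amino group or a dimethylamino group at this position.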